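Para-methoxy amide in the hydroxychromone acrylamide series

The source may hold more compounds than are shown below. What is called first, only, known or untested is meant among the compounds shown, and "the series" means these compounds.

Working notes. The series shares a hydroxychromone acrylamide core carrying an amide nitrogen; compound 1 `Cc1ccc(CNC(=O)/C=C/c2coc3cc(O)ccc3c2=O)cc1` bears a 4-methylbenzyl group on that nitrogen, compound 2 `O=C(/C=C/c1coc2cc(O)ccc2c1=O)Nc1ccccc1` a phenyl. In a functional assay on L02 cells (Homo sapiens) for inhibition, read by MTT assay, with a stated time of 48 h (a higher number here means a weaker inhibitor, a lower number a stronger inhibitor), compound 1 gives only a limit, > 200000 nM. In this assay compound 2 likewise gives only a limit, > 200000 nM. Among the compounds with values here, the step that the two limits leave unreadable from compound 1 to compound 2 therefore cannot be read in size or direction; the two values together show only that both compounds sit at the limit of > 200000 nM in this assay, at which 2 of the 2 values shown sit.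

Compound 3 `COc1ccc(NC(=O)/C=C/c2coc3cc(O)ccc3c2=O)cc1` is the next member. Its change from compound 2 is methoxy in place of hydrogen on an aromatic carbon. Within the data shown here, no measured step bears on this change: the single measured step is unreadable, and no other pair differs by a methoxy on an aromatic carbon. Compound 2 stands at a limit, so there is no anchor number from which to measure a step, and nothing in the data points to a gain of potency strong enough to bring a value into the readable range.

The expected step is a step that the limit leaves unreadable from compound 2 to compound 3, not expected to exceed the scatter. Compound 3 is expected in this assay at 300000 nM, in the range 150000 nM to 1000000 nM, most likely again reported only as a limit.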

Compound 3, half-maximal inhibitory concentration: > 200000 nM
Compound 3: a limit, no number; the forecaster's own chance of this, stated with the estimate: 85%; the middle value does not contradict the limit.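

Compound 3 gives only a limit in this assay, and its steps from compound 1 and compound 2 cannot be read in size or direction. Compound 1, compound 2 and compound 3 share one reading: the limit of > 200000 nM in this assay, at which 3 of the 3 values shown sit. The compounds shown leave open whether any amide substituent on the shared core gives a readable value in this assay at all.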